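Replacing a methylbenzyl group with a trifluorobenzyl group

The compounds below may be only part of what the source reports. "The series", "measured", "known", "first", "only" and "open" are said of these compounds alone.

This account follows a single change made to compound 1, whose structure is `CCCn1c(=O)c2nc(-c3cnn(Cc4cccc(C)c4)c3)[nH]c2n(CCC)c1=O`. In an in vitro assay on HEK293 cells for displacement of a labelled ligand from adenosine receptor A2b (Homo sapiens) (a lower number here means a stronger inhibitor, a higher number a weaker inhibitor), compound 1 gives 36 nM. Among the three compounds measured so far, compound 1 stands second highest: compound 3, `CCn1c(=O)c2nc(-c3cnn(Cc4ccccc4)c3)[nH]c2n(CC)c1=O`, gives 19 nM in this assay, which lies within the scatter of the value for compound 1, while compound 2, `CC(C)Cn1c(=O)c2nc(-c3cnn(Cc4cccc(C(F)(F)F)c4)c3)[nH]c2n(CC(C)C)c1=O`, gives 300 nM, a number clearly higher than that of compound 1. For the measured compounds named here, compound 3 and compound 2 each differ from compound 1 in more than one place, so no single step between them can be isolated.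

The new compound is compound 4, `CCCn1c(=O)c2nc(-c3cnn(Cc4c(F)cc(F)cc4F)c3)[nH]c2n(CCC)c1=O`. It differs from compound 1 in one place only: 2,4,6-trifluorophenyl in place of 3-methylphenyl on a saturated chain carbon bound to an aromatic nitrogen. Going by the values given here, no measured pair shows this difference, so its effect is unknown. Compound 4 is expected to give a value close to that of compound 1, and the step of a 1.4-fold higher number from compound 1 to compound 4 (0.14 log units; within the scatter) is estimated to stay within the scatter. The estimate for compound 4 in this assay is 50 nM, with a range from 15 nM to 170 nM.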

Compound 4, inhibition constant: 650 nM
The estimate for compound 4 lay 13-fold (1.11 log units) below the measured number; the measured number lies above the stated range.
By their numbers in this assay, from the lowest: compounds 3 and 1 (each within the scatter of the next); then compound 2; then compound 4.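

In this assay, exchanging 3-methylbenzyl for 2,4,6-trifluorobenzyl gives an 18-fold higher number from compound 1 to compound 4 (1.26 log units; beyond the scatter) and so shows that the group on the saturated chain carbon bound to an aromatic nitrogen can strongly change the number. The earlier compounds shown here could not show this, since they differ from compound 1 in more than one place and offered no single step to read. No measurement shown accounts for the size of this step.

The compounds shown leave open which part of the change carries the step, since the methyl group leaves and the three fluorines enter together; a benzyl ring bearing a single fluorine or a methoxy group would bear on that. From the compounds shown here alone, it also remains open whether the step would hold with other chains on the shared core.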